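Three thiazole acetic acids at the prostaglandin D2 receptor 2

The compounds below may be only part of what the source reports. "The series", "measured", "known", "first", "only" and "open" are said of these compounds alone.

Measured so far:
compound 1, `O=C(O)Cc1sc(C(c2ccc(F)cc2)c2ccc(F)cc2)nc1-c1cccc(F)c1`, 18 nM
compound 2, `NS(=O)(=O)c1cccc(-c2nc(C(c3ccc(F)cc3)c3ccc(F)cc3)sc2CC(=O)O)c1`, 710 nM
compound 3, `O=C(O)Cc1sc(C(c2ccc(F)cc2)c2ccc(F)cc2)nc1-c1cn[nH]c1`, 220 nM

In an in vitro functional assay on HEK285-7 cells for antagonist activity at prostaglandin D2 receptor 2 (Homo sapiens), read by BRET and beta-arrestin recruitment (a lower number here means a stronger inhibitor, a higher number a weaker inhibitor), compound 3 stands second highest of the three numbers; its nearest neighbour is compound 2, a 3.2-fold lower number from compound 2 to compound 3 (0.51 log units; beyond the scatter), and its furthest is compound 1, a 12-fold higher number from compound 1 to compound 3 (1.09 log units; beyond the scatter). Compound 4, `Cc1cc(-c2nc(C(c3ccc(F)cc3)c3ccc(F)cc3)sc2CC(=O)O)cnc1N`, differs from compound 3 in one place: 6-amino-5-methylpyridin-3-yl in place of 1H-pyrazol-4-yl on an aromatic carbon. Within the data shown here, two measured steps bear on this. Replacing a six-membered aromatic ring with the five-membered 1H-pyrazol-4-yl gave a 12-fold higher number from compound 1 to compound 3 (1.09 log units; beyond the scatter), whereas the same five-membered ring in place of 3-sulfamoylphenyl gave a 3.2-fold lower number from compound 2 to compound 3 (0.51 log units; beyond the scatter). A six-membered ring thus ranged on both sides of compound 3 in this assay, depending on its substituent, and the 6-amino-5-methylpyridin-3-yl that enters carries one donor and two acceptors, placing it between the cases of compound 1 and compound 2. The expected step for compound 4 is therefore a 1.5-fold lower number from compound 3 to compound 4 (0.17 log units; within the scatter), a lowering that may not clear the scatter. Compound 4 is estimated at 150 nM, within 40 nM to 600 nM.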

Compound 4, half-maximal inhibitory concentration: > 100000 nM
Compound 4: no number, only a limit (the forecaster's own chance of this, stated with the estimate: 2%); middle value at least 660-fold (2.82 log units) away from the limit.
By their numbers in this assay, from the lowest: compound 1; then compound 3; then compound 2. At a limit, above all of these: compound 4.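

In this assay compound 4 gives > 100000 nM, which is a limit of the assay and not a number: the limit of > 100000 nM in this assay, at which 1 of the 4 values shown sits. This change gives an at least 450-fold higher number from compound 3 to compound 4 (2.65 log units; beyond the scatter), while the same group gives an at least 140-fold higher number from compound 2 to compound 4 (2.14 log units; beyond the scatter) and an at least 5500-fold higher number from compound 1 to compound 4 (3.74 log units; beyond the scatter). Compound 1, compound 2 and compound 3 all kept a measured number with different rings at this position, so 6-amino-5-methylpyridin-3-yl is the first group shown here to reach the limit of the assay.

The compounds shown do not separate the contributions of the ring nitrogen, the amino group and the methyl group to this step. From the compounds shown here alone, it also remains open whether the step would persist with a hydroxyl or a methoxy group in place of the amino group on the same six-membered ring.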